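Ring methoxy on the shared core of compound 1

A few compounds are considered here, and "the series" means these few. Any claim that something is new, unique, unknown or untested is made for them only; others in the source may bear on it.

Measured so far:
- compound 1 `CC(C)(C)OC(=O)/C=C1/C(=O)Nc2ccccc21`: 59.6%
- compound 2 `CN1C(=O)/C(=C/C(=O)OC(C)(C)C)c2ccccc21`: 57.1%

In a functional assay on OVCAR-3 cells (Homo sapiens) for inhibition, read by CCK-8 assay, with a stated time of 72 h, tested at 20 uM (on this read-out higher numbers stand for more inhibition of growth at the one concentration tested and lower numbers for less inhibition of growth), compound 1 gives 59.6% and compound 2 gives 57.1%; the two numbers lie within the scatter of each other, so no order between them can be read. Going by the values given here, the only measured step, a number 2.5 percentage points lower from compound 1 to compound 2 (within the scatter), concerns the methyl in place of hydrogen on the amide-type nitrogen in the ring and changes nothing beyond the scatter.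

Compound 3 `COc1cccc2c1NC(=O)/C2=C/C(=O)OC(C)(C)C` differs from compound 1 by methoxy in place of hydrogen on an aromatic carbon, on a six-membered aromatic ring of carbon only that is part of the fused system of two rings. Among the compounds with values here, no measured step touches this ring, so the nitrogen step bears on it only as a sign that the core so far tolerates small additions without a shift beyond the scatter. The step of a number 2.6 percentage points lower from compound 1 to compound 3 (within the scatter) is therefore expected to stay within the scatter. For compound 3 the estimate is 57%, with a range from 40% to 72%.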

Compound 3, percent growth inhibition at one concentration: 57.1%
Compound 3: the middle estimate sits 0.1 percentage points below what was measured, within the range that was stated.
By their numbers in this assay, from the lowest: compounds 2, 3 and 1 (each within the scatter of the next).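

In this assay methoxy in place of hydrogen gives a number 2.5 percentage points lower from compound 1 to compound 3 (within the scatter) on an aromatic carbon of the six-membered aromatic ring of carbon only, so this part of the shared core now has a measured step of its own. At this position, ortho to a fused ring and meta to a fused ring, a group with one hydrogen-bond acceptor leaves the number within the scatter, as the methyl on the amide-type nitrogen did in the step from compound 1 to compound 2. Nothing on hand gives a reason for this result.

From the compounds shown here alone, whether an amine, a carboxylic acid or a longer alkoxy chain at this carbon would shift the number beyond the scatter stays open. The compounds shown also leave open how methoxy behaves on the other aromatic carbons of this ring.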